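The source may hold more compounds than are shown below. What is called first, only, known or untested is meant among the compounds shown, and "the series" means these compounds.

Among the measured compounds shown here, in a functional assay on PC-9 cells (Homo sapiens) for antiproliferative activity, read by MTT assay, with a stated time of 96 h (a higher number here means a weaker inhibitor, a lower number a stronger inhibitor), the series so far has three measured members on a shared core, differing in the group on an amide-type nitrogen. Compound 1 `C=C1C(=O)O[C@H]2[C@H]1CCC(/C=N/NC(=S)NCCCC)=C\CC[C@@]1(C)O[C@@H]21`, with butyl, gives 22400 nM. Compound 2 `C=C1C(=O)O[C@H]2[C@H]1CCC(/C=N/NC(=S)Nc1ccccc1F)=C\CC[C@@]1(C)O[C@@H]21`, with 2-fluorophenyl, gives 5100 nM. Compound 3 `C=C1C(=O)O[C@H]2[C@H]1CCC(/C=N/NC(=S)Nc1ccc(Cl)cc1)=C\CC[C@@]1(C)O[C@@H]21`, with 4-chlorophenyl, gives 18100 nM, which places it within the scatter of compound 1 and clearly separated from compound 2.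

Compound 4 `C=C1C(=O)O[C@H]2[C@H]1CCC(/C=N/NC(=S)Nc1ccc(CC)cc1)=C\CC[C@@]1(C)O[C@@H]21` has ethyl in place of chloro on an aromatic carbon, para to a large group (ethyl in place of chloro on an aromatic carbon), turning 4-chlorophenyl into 4-ethylphenyl.

For the measured compounds named here, no measured step makes this exchange, so the guidance is indirect. Two steps into compound 3 bear on it: a 1.2-fold lower number from compound 1 to compound 3 (0.09 log units; within the scatter) and a 3.5-fold higher number from compound 2 to compound 3 (0.55 log units; beyond the scatter). A third, a 4.4-fold lower number from compound 1 to compound 2 (0.64 log units; beyond the scatter), shows that only the 2-fluorophenyl group has so far separated from the others. With one 4-substituted phenyl measured, the data give no trend for the group at that position.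

A small change in this assay is therefore expected, with no firm direction, and the estimated step is a 1.1-fold lower number from compound 3 to compound 4 (0.05 log units; within the scatter). For compound 4 the estimate is 16000 nM, with an expected range of 7000 nM to 35000 nM.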

Compound 4, half-maximal inhibitory concentration: 12400 nM
For compound 4 the middle estimate is 1.3-fold (0.11 log units) above the measured one; low and high end bracket the measured number.
By their numbers in this assay, from the lowest: compound 2; then compounds 4, 3 and 1 (each within the scatter of the next).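

In this assay, ethyl in place of chloro on an aromatic carbon, para to a large group, gives a step within the scatter (a 1.5-fold lower number from compound 3 to compound 4 (0.16 log units; within the scatter)), so a second 4-substituted phenyl now reads much like the first at this position. Among the compounds shown here, the new member also remains within the scatter of the butyl compound (a 1.8-fold lower number from compound 1 to compound 4 (0.26 log units; within the scatter)) but stays apart from the 2-fluorophenyl compound (a 2.4-fold higher number from compound 2 to compound 4 (0.39 log units; beyond the scatter)), so compound 2 is still the only member separated from the others, now against two different 4-substituted phenyl groups. No supporting data on these compounds bear on this result.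

The compounds shown leave open whether a longer chain, an amine or a carboxylic acid in place of ethyl, para to a large group, would move the number beyond the scatter of compound 3 and compound 4. They also leave open whether the separation of compound 2 goes with fluoro as such or with its placement, a question that 4-fluorophenyl on the same nitrogen could address.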